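Swapping methyl for bromine on the sulfonyl arm

This account rests on a few compounds, and the source may have more. Where it says the series, first, only, none or still open, it means among the compounds named here.

Compound 1 `CN(C(=O)c1ccccc1)c1ccc2[nH]c(-c3n[nH]c4ccccc34)cc2n1`: in a functional assay on HCT-116 cells (Homo sapiens) for antiproliferative activity, read by MTT assay, with a stated time of 72 h (a higher number here means a weaker inhibitor, a lower number a stronger inhibitor), compound 1 gives 10600 nM.
Compound 2 `CN(C(=O)c1ccco1)c1ccc2[nH]c(-c3n[nH]c4ccccc34)cc2n1`: in this assay compound 2 gives 30000 nM.
Compound 3 `Cc1ccc(S(=O)(=O)N(C)c2ccc3[nH]c(-c4n[nH]c5ccccc45)cc3n2)cc1`: in this assay compound 3 gives 13300 nM.

All three compounds share one core and differ only in the group carried on the methylated nitrogen. Compound 3 stands second highest of the three numbers: its step from compound 1 is within the scatter (a 1.3-fold higher number from compound 1 to compound 3 (0.10 log units; within the scatter)), while its step from compound 2 is modest and beyond it (a 2.3-fold lower number from compound 2 to compound 3 (0.35 log units; beyond the scatter)). The remaining step, a 2.8-fold higher number from compound 1 to compound 2 (0.45 log units; beyond the scatter), is also modest. Going by the values given here, no measured step is large; swapping the entire arm moves the number only a little.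

Compound 4 `CN(c1ccc2[nH]c(-c3n[nH]c4ccccc34)cc2n1)S(=O)(=O)c1ccc(Br)cc1` differs from compound 3 by bromo in place of methyl on an aromatic carbon. Among the compounds with values here, no measured step touches this ring, so nothing bears on it directly; the only guide is that even whole-arm exchanges stayed modest. A change of one atom on the outer ring is therefore expected to stay within the scatter, with no clear direction. Compound 4 is estimated at 12000 nM, with a range from 5000 nM to 30000 nM, which means an expected step of a 1.1-fold lower number from compound 3 to compound 4 (0.04 log units; within the scatter).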

Compound 4, half-maximal inhibitory concentration: 9850 nM
Compound 4: the middle estimate sits 1.2-fold (0.09 log units) above what was measured, within the range that was stated.
By their numbers in this assay, from the lowest: compounds 4, 1 and 3 (each within the scatter of the next); then compound 2.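

In this assay, going by these compounds alone, the outer ring of the sulfonyl arm is now tested for the first time, and the exchange on this aromatic carbon gives a 1.4-fold lower number from compound 3 to compound 4 (0.13 log units; within the scatter) as its result, so methyl and bromo cannot be told apart here. The bromo compound also cannot be told apart from the benzoyl compound, with a 1.1-fold lower number from compound 1 to compound 4 (0.03 log units; within the scatter) as the step, whereas the furan-2-yl carbonyl compound stays apart, with a 3.0-fold lower number from compound 2 to compound 4 (0.48 log units; beyond the scatter) as the step, so compound 2 has the highest number of the four and the other three form one group. Nothing measured here explains why these numbers fall as they do.

From the compounds shown here alone, it remains open whether a very different group on this same aromatic carbon, such as an amine or a carboxylic acid, would stay within the scatter of compound 3 or move the number clearly in either direction. Going by these compounds, the methyl on the nitrogen is common to all four compounds, so the effect of replacing it with a hydrogen or a longer chain also remains unknown.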